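Nitro in Place of Amino on the Fluorinated Ring

The compounds below may be only part of what the source reports. "The series", "measured", "known", "first", "only" and "open" are said of these compounds alone.

Measured compounds:
compound 1 `COc1cc(OC)c(/C=C/S(=O)(=O)Cc2ccc(F)c(N)c2)c(OC)c1`, 2500 nM
compound 2 `COc1cc(OC)c(/C=C/S(=O)(=O)Cc2ccc(OC)c(N)c2)c(OC)c1`, 2.5 nM
compound 3 `COc1cc(OC)c(/C=C/S(=O)(=O)Cc2ccc(Cl)c(N)c2)c(OC)c1`, 10 nM

Three compounds sharing one core were tested in a functional assay on K562 cells (Homo sapiens) for cytotoxicity, read by trypan blue exclusion, with a stated time of 96 h; on this read-out lower numbers stand for stronger inhibition and higher numbers for weaker inhibition. Compound 1 stands highest of the three numbers. The nearest is compound 3, reached by a 250-fold lower number from compound 1 to compound 3 (2.40 log units; beyond the scatter), and the furthest is compound 2, reached by a 1000-fold lower number from compound 1 to compound 2 (3.00 log units; beyond the scatter). Between those two, a 4.0-fold higher number from compound 2 to compound 3 (0.60 log units; beyond the scatter) separates them.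

Compound 4 `COc1cc(OC)c(/C=C/S(=O)(=O)Cc2ccc(F)c([N+](=O)[O-])c2)c(OC)c1` is not yet measured. It differs from compound 1 in one place: nitro in place of amino on an aromatic carbon. Among the measured compounds shown here, none of the measured steps bears on this change; all three alter the group that sits para on the same ring while the amino stays in place, so they give no direct guide to what exchanging the amino for a nitro does. With nothing to draw on, the estimate for compound 4 is anchored on compound 1 and kept wide. Compound 4 is expected to give about 3000 nM in this assay, with a range from 500 nM to 20000 nM. That estimate amounts to a 1.2-fold higher number from compound 1 to compound 4 (0.08 log units; within the scatter), which is not expected to lie clearly beyond the scatter, but the uncertainty in either direction is large.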

Compound 4, half-maximal inhibitory concentration: 25000 nM
Compound 4: the middle estimate sits 8.3-fold (0.92 log units) below what was measured, outside the stated range (above it).
By their numbers in this assay, from the lowest: compound 2; then compound 3; then compound 1; then compound 4.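

In this assay, nitro in place of amino, with the fluoro group left untouched, gives a 10-fold higher number from compound 1 to compound 4 (1.00 log units; beyond the scatter). Among the compounds shown here, the earlier steps changed only the fluoro, methoxy or chloro group while the amino stayed in place, so this is the first sign that the number also responds to the group ortho to the fluoro group, and that the change of amino to nitro here moves it in the direction of weaker inhibition. No measurement shown offers an explanation for this step.

As far as these compounds go, whether nitro in place of amino would act in the same way with the methoxy group of compound 2 or the chloro group of compound 3 remains open. Also open, from the compounds shown here alone, is how a hydroxyl, an acetamide or a methylamino group on this aromatic carbon would compare with amino and nitro, and so whether the amino itself or merely the absence of nitro lies behind the lower number of compound 1.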